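The source may report more compounds than this note shows. Statements on the series, on what has been measured and on what is new or still open speak of the compounds shown alone.

Two compounds of this nitrile series carry numbers in an assay on isolated protein for inhibition of cathepsin S (Homo sapiens), read by fluorescence, with a stated time of 20 min; on this read-out higher numbers stand for weaker inhibition and lower numbers for stronger inhibition. Compound 1 `N#CCNC(=O)[C@@H]1C[C@@H](S(=O)(=O)c2ccccc2Cl)C[C@H]1C(=O)N1CCOCC1` gives 0.5 nM. Compound 2 `N#CC1(NC(=O)[C@@H]2C[C@@H](S(=O)(=O)c3ccccc3)C[C@H]2C(=O)N2CC3CCC(C2)O3)CC1` gives 1 nM, and this sits within the scatter of the number for compound 1, so the two are not separated. Compound 3 `N#CC1(NC(=O)[C@@H]2C[C@@H](S(=O)(=O)c3ccccc3)C[C@H]2C(=O)N2CC(O)C2)CC1` is not yet measured; it differs from compound 2 only on a carbonyl carbon: a group of 5 heavy atoms (3 carbon, 1 nitrogen, 1 oxygen; one four-membered non-aromatic ring with 1 hetero atom) in place of a group of 8 heavy atoms (6 carbon, 1 nitrogen, 1 oxygen; one five-membered non-aromatic ring with 1 hetero atom, one six-membered non-aromatic ring with 2 hetero atoms), on a carbonyl carbon. Among the compounds with values here, no measured pair shows this kind of exchange, so the step is an open question. The step from compound 2 to compound 3 is expected to be small, a 2.0-fold higher number from compound 2 to compound 3 (0.30 log units; within the scatter), not clearly beyond the scatter. Compound 3 is therefore estimated at 2 nM, with a range of 0.5 nM to 8 nM.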

Compound 3, half-maximal inhibitory concentration: 7 nM
The estimate for compound 3 lay 3.5-fold (0.54 log units) below the measured number; the range from low to high includes it.
By their numbers in this assay, from the lowest: compounds 1 and 2 (each within the scatter of the next); then compound 3.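

At this carbonyl carbon the amide group is not interchangeable in this assay: 3-hydroxyazetidin-1-yl in place of the larger group of compound 2 gives a 7.0-fold higher number from compound 2 to compound 3 (0.85 log units; beyond the scatter), a modest step. Within the data shown here, this is the first single-place change read, and it shows that this position responds to the exchange. No available evidence bears on the origin of the step.

The exchange alters ring system, size and hydrogen-bond donor count together, so their shares remain unresolved. Plain azetidin-1-yl or 3-aminoazetidin-1-yl at this carbonyl carbon would help separate them.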